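Bromo for chloro: a halogen swap on compound 3

A few compounds are considered here, and "the series" means these few. Any claim that something is new, unique, unknown or untested is made for them only; others in the source may bear on it.

Measured so far in an ADME assay on MT4 cells (Homo sapiens) for cytotoxicity, read by MTT assay, with a stated time of 5 days; a lower number here means that less compound is tolerated, a higher number that more compound is tolerated:
compound 1 `O=C1N(Cc2ccc(Cl)cc2Cl)c2cccn2S(=O)(=O)N1Cc1ccccc1`: 218000 nM
compound 2 `CC(C)=CCN1C(=O)N(Cc2ccccc2)S(=O)(=O)n2cccc21`: 226000 nM
compound 3 `O=C1N(Cc2ccccc2Cl)c2cccn2S(=O)(=O)N1Cc1ccccc1`: only a limit, > 291000 nM

Compound 3 stands at the upper edge of what this assay reports: its result is a limit, not a number, and it sits at the limit of > 291000 nM in this assay, at which 1 of the 3 values shown sits. The steps among the measured compounds are all small. The step of an at least 1.3-fold higher number from compound 1 to compound 3 (0.12 log units; that floor lies within the scatter) replaces chloro with hydrogen on an aromatic carbon, and the steps of a 1.0-fold higher number from compound 1 to compound 2 (0.02 log units; within the scatter) and an at least 1.2-fold higher number from compound 2 to compound 3 (0.10 log units; that floor lies within the scatter) exchange whole groups on the saturated chain carbon, none of them moving the read-out beyond the scatter.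

Compound 4 `O=C1N(Cc2ccccc2Br)c2cccn2S(=O)(=O)N1Cc1ccccc1` differs from compound 3 by bromo in place of chloro on an aromatic carbon, on an aromatic carbon of a six-membered aromatic ring of carbon only, ortho to a large group. The nearest measured step is an at least 1.3-fold higher number from compound 1 to compound 3 (0.12 log units; that floor lies within the scatter), where even removing the chloro altogether changed little. Compound 4 is therefore expected to behave like compound 3, with a step of about a number no higher from compound 3 to compound 4 (the limit leaves the size open), no change beyond the scatter, and most likely another limit. The estimate for compound 4 is 291000 nM, between 150000 nM and 600000 nM.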

Compound 4, half-maximal cytotoxic concentration: 226000 nM
Compound 4: middle estimate off by 1.3-fold (0.11 log units), on the high side; the range from low to high includes it.
By their numbers in this assay, from the lowest: compounds 1, 2 and 4 (each within the scatter of the next). At a limit, above all of these: compound 3.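

In this assay, the exchange of chloro for bromo on an aromatic carbon of a six-membered aromatic ring of carbon only, ortho to a large group, gives an at least 1.2-fold lower number from compound 3 to compound 4 (0.10 log units; that floor lies within the scatter), the first change shown at this place that keeps a halogen there. The 2-bromophenyl group also gives no change at the digits printed from compound 2 to compound 4 (within the scatter) and a 1.0-fold higher number from compound 1 to compound 4 (0.02 log units; within the scatter), so on the saturated chain carbon bound to an amide-type nitrogen in a ring it joins 2-methylprop-1-en-1-yl and 2,4-dichlorophenyl with no step beyond the scatter. The bromo exchange can be read only from one side, and its true size stays unknown, because compound 3 holds a limit and not a number: the limit of > 291000 nM in this assay, at which 1 of the 4 values shown sits.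

The compounds shown leave open whether a group other than a halogen at this place, such as a methoxy group, an amine or a carboxylic acid, would move the read-out beyond the scatter. They also leave open how far compound 3 truly lies from the other compounds, since its result gives only a bound.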